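The source may hold more compounds than are shown below. What is called first, only, known or untested is meant among the compounds shown, and "the series" means these compounds.

Three close relatives share one core and differ only in the chloro groups on the aromatic ring that carries the carboxy group. In a functional assay (aorta) for inhibition, with Oryctolagus cuniculus as the target (on this read-out higher numbers stand for weaker inhibition and lower numbers for stronger inhibition), compound 1 (`CCCCc1ncc(/C=C(\Cc2cccs2)C(=O)O)n1Cc1ccc(C(=O)O)cc1Cl`) gives 0.02 nM, compound 2 (`CCCCc1ncc(/C=C(\Cc2cccs2)C(=O)O)n1Cc1ccc(C(=O)O)c(Cl)c1`) gives 0.13 nM and compound 3 (`CCCCc1ncc(/C=C(\Cc2cccs2)C(=O)O)n1Cc1ccc(C(=O)O)c(Cl)c1Cl`) gives 0.18 nM. Compound 2 therefore sits within the scatter of compound 3, while its number is clearly higher than that of compound 1.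

Compound 4 (`CCCCc1ncc(/C=C(\Cc2cccs2)C(=O)O)n1Cc1cc(Cl)c(C(=O)O)cc1Cl`) is compound 2 with one change: chloro in place of hydrogen on an aromatic carbon. This is a chloro in place of hydrogen on an aromatic carbon, ortho to a large group.

For the measured compounds named here, the closest precedent for adding a chloro to this ring is a 1.4-fold higher number from compound 2 to compound 3 (0.14 log units; within the scatter). The same kind of change elsewhere gave a modest move, a 9.0-fold higher number from compound 1 to compound 3 (0.95 log units; beyond the scatter). Shifting the chloro alone gave a 6.5-fold higher number from compound 1 to compound 2 (0.81 log units; beyond the scatter), so its location on the ring can matter. Going by the values given here, no measured compound has the chloro arrangement of compound 4, which keeps the range wide.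

With compound 3 at 0.18 nM as the nearest guide, no change beyond the scatter is expected in this assay. The expected step is a 1.2-fold higher number from compound 2 to compound 4 (0.06 log units; within the scatter). For compound 4 the estimated value is 0.15 nM, with an expected range from 0.05 nM to 0.5 nM.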

Compound 4, antagonist equilibrium constant: 1.58 nM
For compound 4 the middle estimate is 11-fold (1.02 log units) below the measured one, outside the stated range (above it).
By their numbers in this assay, from the lowest: compound 1; then compounds 2 and 3 (each within the scatter of the next); then compound 4.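

Adding a chloro to compound 2 is not a neutral change on this ring. Placed ortho to a large group, meta to a carboxy group and para to a chloro group, it gives a 12-fold higher number from compound 2 to compound 4 (1.08 log units; beyond the scatter) in this assay, whereas the other chloro addition to the same compound gave only a 1.4-fold higher number from compound 2 to compound 3 (0.14 log units; within the scatter). Starting from compound 1, a chloro in place of hydrogen gives a 79-fold higher number from compound 1 to compound 4 (1.90 log units; beyond the scatter), so this one change has no single size here, and the outcome differs with where the new chloro enters and where the existing one sits: the same change on two cores in this assay, a 1.4-fold higher number (0.14 log units; within the scatter) from compound 2 to compound 3 and a 79-fold higher number (1.90 log units; beyond the scatter) from compound 1 to compound 4, 57-fold (1.76 log units) apart, beyond the scatter of two such steps Two of the additions do match in size, but the small step from compound 2 to compound 3 goes against any general rule drawn from them: the same change on two cores in this assay, a 9.0-fold higher number (0.95 log units; beyond the scatter) from compound 1 to compound 3 and a 12-fold higher number (1.08 log units; beyond the scatter) from compound 2 to compound 4, 1.4-fold (0.13 log units) apart, within the scatter of two such steps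

On these data alone, the ring in these compounds carries only chloro or hydrogen beside its carboxy group, so it remains open whether a fluoro or a methyl at the same place would give a step of this size. As far as these compounds go, it also remains open whether the chloro would give the same step with a longer chain on the shared core.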